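The source may report more compounds than this note shows. Statements on the series, on what has been measured and on what is new or still open speak of the compounds shown alone.

Within the data shown here, in a functional assay on NCI-H522 cells (Homo sapiens) for cytotoxicity, with a stated time of 3 days (on this read-out higher numbers stand for weaker inhibition and lower numbers for stronger inhibition), compound 1 `C#Cc1sc(-c2ccc(F)cc2)nc1C(=O)OCC` gives 3530 nM, and this is the only true number available so far. Compound 2 `C#CCNC(=O)c1csc(C#Cc2ccccc2)n1` offers no number to compare with, since its result of > 40000 nM is a limit of the assay.

The next compound keeps the core of compound 1 and changes a single group. In compound 3 `C=Cc1sc(-c2ccc(F)cc2)nc1C(=O)OCC`, vinyl takes the place of ethynyl on an aromatic carbon, next to the ring sulfur and next to the ring atom that bears the ethoxycarbonyl group: vinyl in place of ethynyl on an aromatic carbon. The triple bond becomes a double bond, while the count of heavy atoms stays the same.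

Among the measured compounds shown here, no measured pair shows what such a swap does in this assay, so the expectation rests only on the small size of the change and on compound 1 at 3530 nM. A modest loss is expected, slightly beyond the usual scatter, and the estimated move is a 2.5-fold higher number from compound 1 to compound 3 (0.41 log units; beyond the scatter). For compound 3 the expected value is 9000 nM, with an estimated range from 2500 nM to 35000 nM.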

Compound 3, half-maximal inhibitory concentration: > 40000 nM
Compound 3: a limit, no number; the forecaster's own chance of this, stated with the estimate: 20%; middle value at least 4.4-fold (0.64 log units) from the limit.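

In this assay, among these compounds, this one change at the aromatic carbon next to the ring sulfur gives an at least 11-fold higher number from compound 1 to compound 3 (1.05 log units; beyond the scatter), the first measured pair to show that vinyl in place of ethynyl here costs a large part of the activity, even though the count of heavy atoms stays the same. The result for compound 3, > 40000 nM, is a limit of the assay and not a number. The step therefore marks the smallest loss consistent with the data and not its true size, and the same limit recurs among the few results available: the limit of > 40000 nM in this assay, at which 2 of the 3 values shown sit.

Among the compounds shown here, it remains open whether ethynyl is the only group at this position that keeps a measurable value, since a nitrile, an ethyl group or a plain hydrogen there would each give a further comparison with compound 1. From the compounds shown here alone, it is also open whether ethynyl keeps its advantage when the ethoxycarbonyl group beside it gives way to a carboxylic acid or an amide, because compound 2 differs from compound 1 in more than one place and cannot answer that.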